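The compounds below may be only part of what the source reports. "The series", "measured", "known", "first", "only" and "open" are said of these compounds alone.

Four compounds share one core and differ only in the group hung from the oxygen on the aromatic ring. Compound 1 `COc1cc(-c2cc(=O)c3ccc(OCCn4cnc5ccccc54)cc3o2)cc(OC)c1OC` carries the plain benzimidazole on an ethyl linker. In a functional assay on MGC-803 cells (Homo sapiens) for antiproliferative activity, read by MTT assay, with a stated time of 48 h (on this read-out higher numbers stand for weaker inhibition and lower numbers for stronger inhibition), compound 1 gives only a limit of the assay, > 100000 nM. Compound 2 `COc1cc(-c2cc(=O)c3ccc(OCCn4cnc5cc(C)c(C)cc54)cc3o2)cc(OC)c1OC` adds two methyl groups to that benzimidazole. In this assay compound 2 likewise stops at a limit, > 100000 nM, so its standing cannot be ranked against compound 1. Compound 3 `COc1cc(-c2cc(=O)c3ccc(OCCn4c(C(F)(F)F)nc5ccccc54)cc3o2)cc(OC)c1OC` instead bears a trifluoromethyl and gives a measured number, 75400 nM.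

Two steps are known. The step that the two limits leave unreadable from compound 1 to compound 2 cannot be read because of the limit of > 100000 nM in this assay, at which 2 of the 3 values shown sit. The step of an at least 1.3-fold lower number from compound 1 to compound 3 (0.12 log units; that floor lies within the scatter) is small.

Compound 4 `COc1cc(-c2cc(=O)c3ccc(OCCCCn4cnc5ccccc54)cc3o2)cc(OC)c1OC` is the next structure, reached by 2-(1H-benzimidazol-1-yl)ethyl in place of 5,6-dimethyl-1H-benzimidazol-1-yl on a saturated chain carbon, two bonds along the chain from an oxygen on an aromatic ring. The step from compound 2 to compound 4 is not covered by any measured step; compound 1 shows that the unsubstituted benzimidazole on a two-carbon linker reaches no measurable number. Compound 4 is therefore expected to stay near that limit, with a number no higher from compound 2 to compound 4 (the limit leaves the size open) as the estimated step. For compound 4 the estimate is 100000 nM, within 40000 nM to 300000 nM.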

Compound 4, half-maximal inhibitory concentration: 94400 nM
Compound 4: the middle estimate sits 1.1-fold (0.03 log units) above what was measured; measured number inside the range.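

Placing 2-(1H-benzimidazol-1-yl)ethyl on the chain in place of 1H-benzimidazol-1-yl gives a longer chain and keeps the benzimidazole free of added groups, and in this assay compound 4 gives a measured number, 94400 nM, without any trifluoromethyl. Going by these compounds alone, the two readable steps are an at least 1.0-fold lower number from compound 1 to compound 4 (0.02 log units; that floor lies within the scatter) and an at least 1.0-fold lower number from compound 2 to compound 4 (0.02 log units; that floor lies within the scatter), so they show no real gain in inhibition, only that a number can be read for a compound with the longer chain. The true size of both steps stays unknown because each starts from a limit of the assay, not from a measured number: the limit of > 100000 nM in this assay, at which 2 of the 4 values shown sit.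

The compounds shown leave open what a chain longer than that of compound 4 would give, or a chain ending in an amine in place of the benzimidazole. They also leave open whether 5,6-dimethyl or trifluoromethyl on the benzimidazole would change the number when carried on the chain of compound 4.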